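Compound 2 and the step to compound 3

This account rests on a few compounds, and the source may have more. Where it says the series, first, only, none or still open, it means among the compounds named here.

Compound 1 `COc1cc(-c2ccnc3cc(-c4ccc5cc[nH]c5c4)nn23)cc(OC)c1OC` gives 23 nM
Compound 2 `COc1cc(-c2ccnc3cc(-c4cccc(C)c4)nn23)cc(OC)c1OC` gives 1080 nM

In a functional assay on MCF7 cells (Homo sapiens) for inhibition, read by CCK-8 assay, with a stated time of 48 h (a lower number here means a stronger inhibitor, a higher number a weaker inhibitor), compound 2 has the higher of the two numbers (1080 nM), so it is the weaker inhibitor of the pair. Compound 3 (`COc1ccc(-c2cc3nccc(-c4cc(OC)c(OC)c(OC)c4)n3n2)cc1N`) keeps the shared core, and one group changes (3-amino-4-methoxyphenyl in place of 3-methylphenyl on an aromatic carbon). Within the data shown here, only one measured step involves this same place (a 47-fold higher number from compound 1 to compound 2 (1.67 log units; beyond the scatter)), and it is large, with 3-methylphenyl on the weak side. Like the 1H-indol-6-yl group of compound 1, the entering group contains nitrogen, but a single pair is thin evidence. A sizeable fall in the number is therefore expected, though smaller than that measured step (a 9.8-fold lower number from compound 2 to compound 3 (0.99 log units; beyond the scatter) is the estimate). For compound 3 the estimated value is 110 nM (expected range 20 nM to 700 nM).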

Compound 3, half-maximal inhibitory concentration: 27 nM
Estimate against measurement, compound 3: 4.1-fold (0.61 log units) above; the range from low to high includes it.
By their numbers in this assay, from the lowest: compounds 1 and 3 (each within the scatter of the next); then compound 2.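

In this assay, this place on the five-membered aromatic ring can carry more than one kind of group with a low number: 3-amino-4-methoxyphenyl in place of 3-methylphenyl gives a 40-fold lower number from compound 2 to compound 3 (1.60 log units; beyond the scatter), which is about the size of the earlier loss, but in the opposite direction. The fused 1H-indol-6-yl group is therefore not the only route to a low number, since a single six-membered ring with the right groups matches it, with a 1.2-fold higher number from compound 1 to compound 3 (0.07 log units; within the scatter). Nothing measured here explains these differences.

The amino and methoxy groups enter together, so the compounds shown leave open how much of the step belongs to each. Also open, as far as these compounds go, is whether a hydroxyl or a methylamino group could stand in for the amino group.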